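A Second Hydroxy Group on the Aryl Hydrazone

The source may report more compounds than this note shows. Statements on the series, on what has been measured and on what is new or still open speak of the compounds shown alone.

For the measured compounds named here, compound 2 `C/C(=N\NC(=O)c1cccc(S(=O)(=O)N2CCOCC2)c1)c1ccc(O)cc1` is the only compound with a number in a functional assay on EC9706 cells (Homo sapiens) for antiproliferative activity, read by MTT assay, with a stated time of 72 h; on this read-out lower numbers stand for stronger inhibition and higher numbers for weaker inhibition: compound 2 gives 71400 nM. Compound 1 `C/C(=N\NC(=O)c1cccc(S(=O)(=O)N2CCOCC2)c1)c1ccc(F)cc1` reaches only a limit, > 100000 nM, which is the limit of > 100000 nM in this assay, at which 1 of the 2 values shown sits. Going by the values given here, the one measured step, an at least 1.4-fold lower number from compound 1 to compound 2 (0.14 log units; that floor lies within the scatter), therefore sets only a floor. Compound 3 `C/C(=N\NC(=O)c1cccc(S(=O)(=O)N2CCOCC2)c1)c1cc(O)ccc1O` carries 2,5-dihydroxyphenyl in place of 4-hydroxyphenyl on a carbon with a double bond to nitrogen. Among the compounds with values here, the single step bearing on it is that floor, too small to promise more than a change within the usual scatter. The estimate for compound 3 in this assay is 50000 nM, in the range 15000 nM to 150000 nM. That amounts to an expected step of a 1.4-fold lower number from compound 2 to compound 3 (0.15 log units; within the scatter).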

Compound 3, half-maximal inhibitory concentration: 3510 nM
For compound 3 the middle estimate is 14-fold (1.15 log units) above the measured one; the whole stated range lies above it.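

Replacing 4-hydroxyphenyl with 2,5-dihydroxyphenyl on the carbon with a double bond to nitrogen gives a change that, unlike the floor from fluoro to hydroxy, clears the scatter: a 20-fold lower number from compound 2 to compound 3 (1.31 log units; beyond the scatter). Against 4-fluorophenyl, the same group gives an at least 28-fold lower number from compound 1 to compound 3 (1.45 log units; beyond the scatter). That second step is only a floor because compound 1 stands at a limit of the assay: the limit of > 100000 nM in this assay, at which 1 of the 3 values shown sits.

Going by these compounds, what remains open is whether a methoxy group or an amine in place of the added hydroxy group would hold this gain.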